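Substituent exchange on the fused ring of the shared core

A few compounds are considered here, and "the series" means these few. Any claim that something is new, unique, unknown or untested is made for them only; others in the source may bear on it.

Measured so far in an assay on CHO cells for inhibition of sodium- and chloride-dependent glycine transporter 1 (Homo sapiens), read by scintillation counting; on this read-out lower numbers stand for an effect already at smaller amounts and higher numbers for an effect only at larger amounts of compound:
compound 1, `Cc1cccc2c1CN(C(=O)c1cc(S(C)(=O)=O)ccc1O[C@@H](C)C(F)(F)F)C2`, gives 3360 nM
compound 2, `COc1cccc2c1CN(C(=O)c1cc(S(C)(=O)=O)ccc1O[C@@H](C)C(F)(F)F)C2`, gives 1940 nM

Compound 1 and compound 2 share one core and differ in a single group, methyl against methoxy, on an aromatic carbon. The step of a 1.7-fold lower number from compound 1 to compound 2 (0.24 log units; within the scatter) stays within the scatter, so on these two numbers compound 2 is not separated from compound 1; neither can be called the stronger.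

Compound 3, `C[C@H](Oc1ccc(S(C)(=O)=O)cc1C(=O)N1Cc2cccc(C#N)c2C1)C(F)(F)F`, is not yet measured. It is reached from compound 2 by cyano in place of methoxy on an aromatic carbon. Going by the values given here, no measured step exchanges a methoxy for a cyano, so no direct precedent exists. Among the compounds with values here, the one measured exchange on an aromatic carbon, a 1.7-fold lower number from compound 1 to compound 2 (0.24 log units; within the scatter), moved the number within the scatter, and that is the only step bearing on this change. The expected step is therefore a 1.1-fold lower number from compound 2 to compound 3 (0.06 log units; within the scatter), with no movement beyond the scatter in either direction. Compound 3 is estimated at 1700 nM, with a range from 600 nM to 4500 nM.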

Compound 3, half-maximal effective concentration in the sodium- and chloride-dependent glycine transporter 1 assay: 770 nM
Compound 3: the middle estimate sits 2.2-fold (0.34 log units) above what was measured; low and high end bracket the measured number.
By their numbers in the sodium- and chloride-dependent glycine transporter 1 assay, from the lowest: compound 3; then compounds 2 and 1 (each within the scatter of the next).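

In the sodium- and chloride-dependent glycine transporter 1 assay, this aromatic carbon now separates compounds, which the exchange of methyl for methoxy could not do: cyano gives a 2.5-fold lower number from compound 2 to compound 3 (0.40 log units; beyond the scatter) and a 4.4-fold lower number from compound 1 to compound 3 (0.64 log units; beyond the scatter). Both steps are modest, but both lie beyond the scatter, so compound 3 is the strongest of the three shown, and the group on this carbon can move the number measurably. In a physicochemical assay for solubility (a higher number here means a more soluble compound, a lower number a less soluble compound), compound 2 gives 85 ug/mL and compound 3 gives 259 ug/mL. The exchange of methoxy for cyano also raises the number in the physicochemical assay, so on this pair the gain in transporter read-out comes with higher solubility rather than at its cost: the measured solubility of compound 2, 85 ug/mL, and of compound 3, 259 ug/mL, a 3.0-fold higher number (0.48 log units; beyond the scatter)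

As far as these compounds go, with only methyl, methoxy and cyano at this carbon, it remains open whether the lower number is particular to cyano or would also appear with another small group such as chlorine, a primary amide or a carboxylic acid. It also remains open whether the gain in both read-outs would carry over to compounds with a different ether chain on the shared core, since all three compounds shown carry the same one.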